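Swapping a dichlorophenyl for a dimethoxyphenyl on the carbonyl

The source may hold more compounds than are shown below. What is called first, only, known or untested is meant among the compounds shown, and "the series" means these compounds.

Measured so far:
compound 1 `COc1cc(-c2cc(/C=C/C(=O)c3ccc(Cl)c(Cl)c3)[nH]n2)cc(OC)c1OC` — 92%
compound 2 `COc1ccc(-c2cc(/C=C/C(=O)c3cc(OC)c(OC)c(OC)c3)[nH]n2)cc1OC` — 70%
compound 3 `COc1ccc(-c2cc(/C=C/C(=O)c3ccc(N)cc3)[nH]n2)cc1` — 77%

The three compounds were tested in a functional assay on BT-549 cells (Homo sapiens) for cytotoxicity, read by sulforhodamine B assay, with a stated time of 48 h, tested at 1 uM; a lower number here means a stronger effect, a higher number a weaker effect of the compound at the concentration tested. On these numbers compound 1 stands highest, which here means the weakest effect. Its nearest neighbour is compound 3, whose value sits lower by a gap beyond the scatter; compound 2 lies further below, also beyond the scatter. So the compound bearing a 3,4-dichlorophenyl on the carbonyl carbon is the one that holds back the most cells, while the two with oxygen- or nitrogen-bearing groups in that place do more.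

Compound 4 `COc1ccc(C(=O)/C=C/c2cc(-c3cc(OC)c(OC)c(OC)c3)n[nH]2)cc1OC` keeps the shared core of compound 1 and alters one place: 3,4-dimethoxyphenyl in place of 3,4-dichlorophenyl on a carbonyl carbon

Going by the values given here, no measured pair in this set shows the same single change, so the size of the step in this assay is not known from a direct precedent. What the numbers do show is that compound 2 gives 70% and compound 3 gives 77%, both clearly below compound 1. The step from compound 1 to compound 4 is therefore expected to be downward and modest, a number 12 percentage points lower from compound 1 to compound 4 (beyond the scatter), with some chance it stays within the scatter. Compound 4 is estimated to give 80%, in a range from 62% to 98%.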

Compound 4, a percentage reported as activity, at one concentration (the size of the read-out at that concentration, not a potency): 76%
The estimate for compound 4 lay 4 percentage points above the measured number; low and high end bracket the measured number.
By their numbers in this assay, from the lowest: compounds 2, 4 and 3 (each within the scatter of the next); then compound 1.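

In this assay, going by these compounds alone, this is the first pair in the set that differs in one place only: 3,4-dimethoxyphenyl in place of 3,4-dichlorophenyl on a carbonyl carbon gives a number 16 percentage points lower from compound 1 to compound 4 (beyond the scatter). The earlier compounds shown here differed from one another in more than one place, so they could not tie a change in the read-out to this position alone; this pair shows that the group on the carbonyl carbon can by itself shift the result, with the methoxy-bearing ring giving the stronger effect at the concentration tested. Nothing available explains why this swap moves the number, so the result stands as an observation without a known cause.

The compounds shown leave open how other groups on the same carbonyl carbon would read, such as an unsubstituted phenyl, a 3,4-dimethylphenyl or a pyridine ring, which would help show whether the chlorine atoms or the methoxy groups matter more. They also leave open whether the same swap gives a step of similar size when the rest of the shared core carries different groups.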